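Benzyl for phenoxy on the core of compound 1

The source may hold more compounds than are shown below. What is called first, only, known or untested is meant among the compounds shown, and "the series" means these compounds.

Three compounds of this series have a number in an ADME assay for permeability, using PAMPA, with a stated time of 30 min, at pH 7.4; a lower number here means that the compound crosses the layer more slowly, a higher number that the compound crosses the layer faster. Compound 1 `COc1cccc(CNCCCNc2ccnc3cc(Oc4ccc(Cl)cc4)ccc23)c1O` gives 317 10^-6 cm/s, the highest of the three. Compound 3 `c1coc(CNCCCNc2ccnc3cc(-c4cccc5ccccc45)ccc23)c1` gives 237 10^-6 cm/s, a number within the scatter of that of compound 1. Compound 2 `COc1ccc(F)cc1CNCCCNc1ccnc2cc(Cc3ccc(C#N)cc3)ccc12` gives 23 10^-6 cm/s, the lowest number and well beyond the scatter from compound 1. No pair among these three differs in a single place, so no step can be read from them, and compound 2 differs from compound 1 in several parts at once.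

Compound 4 `COc1cccc(CNCCCNc2ccnc3cc(Cc4ccc(F)cc4Cl)ccc23)c1O` has not been measured. It differs from compound 1 in one place: 2-chloro-4-fluorobenzyl in place of 4-chlorophenoxy on an aromatic carbon. The change removes the only hydrogen-bond acceptor of the leaving group and adds one heavy atom. Compound 1 and compound 3 both give high numbers, so the step in this assay from compound 1 to compound 4 is expected to be small, a 1.2-fold lower number from compound 1 to compound 4 (0.09 log units; within the scatter), not beyond the scatter in either direction. Compound 4 is therefore estimated at 260 10^-6 cm/s, with a range from 120 10^-6 cm/s to 480 10^-6 cm/s.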

Compound 4, apparent permeability: 23 10^-6 cm/s
Beside the measured number, compound 4's estimate is 11-fold (1.05 log units) above it; the whole stated range lies above it.
By their numbers in this assay, from the lowest: compounds 2 and 4 (each within the scatter of the next); then compounds 3 and 1 (each within the scatter of the next).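

In this assay, among these compounds, 2-chloro-4-fluorobenzyl in place of 4-chlorophenoxy on an aromatic carbon of the core of compound 1 gives a 14-fold lower number from compound 1 to compound 4 (1.14 log units; beyond the scatter), the first step that can be read. This position is therefore not neutral: one change here, with the rest of compound 1 held, moves the number beyond the scatter. The leaving and entering groups differ both in the atom that joins them to the core and in their halogens, and nothing measured here accounts for the step or assigns it to either difference.

From the compounds shown here alone, whether the step follows the joining atom or the halogens stays open, and a 4-chlorobenzyl group at this place would separate the two. Also open, going by these compounds, is whether a step of this size persists with an amide in place of the secondary amine of the chain.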